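A Fluorine Enters the Phenyl Ring of Compound 2

The compounds below may be only part of what the source reports. "The series", "measured", "known", "first", "only" and "open" are said of these compounds alone.

Compound 1 `Nc1scc(-c2cccc(C(F)(F)F)c2)c1C(=O)c1ccccc1` and compound 2 `Nc1scc(-c2ccccc2)c1C(=O)c1ccccc1` share a core and differ only in that compound 2 carries hydrogen where compound 1 carries trifluoromethyl. In a functional assay on CHO cells for agonist activity at adenosine receptor A1 (Homo sapiens), read by fluorescence and ERK phosphorylation, with stated times of 30 min and 1.5 h, tested at 10 uM (on this read-out lower numbers stand for a weaker effect and higher numbers for a stronger effect at the one concentration tested), compound 1 gives 59%, while compound 2 gives 48%. That single measured step, a number 11 percentage points lower from compound 1 to compound 2 (beyond the scatter), leaves compound 2 with the lowest of the two numbers, with compound 1 as its nearest neighbour above it.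

Compound 3 `Nc1scc(-c2ccccc2F)c1C(=O)c1ccccc1` is the next compound, differing from compound 2 by fluoro in place of hydrogen on an aromatic carbon. Within the data shown here, the only step on hand, a number 11 percentage points lower from compound 1 to compound 2 (beyond the scatter), concerns a different group at a different place, so it bears only loosely on this change; it shows that adding fluorine-bearing substance to that ring went with a modestly higher number. A small rise, near the edge of the scatter, is therefore expected. Compound 3 is estimated to give 53%, with a range from 40% to 66%. The expected step is a number 5 percentage points higher from compound 2 to compound 3 (within the scatter).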

Compound 3, a percentage reported as activity, at one concentration (the size of the read-out at that concentration, not a potency): 68%
Beside the measured number, compound 3's estimate is 15 percentage points below it, and the stated range ends below it.
By their numbers in this assay, from the lowest: compound 2; then compounds 1 and 3 (each within the scatter of the next).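

In this assay, a single fluoro ortho to a large group, on the six-membered aromatic ring of carbon only, is enough for a number 20 percentage points higher from compound 2 to compound 3 (beyond the scatter). This position therefore responds to an exchange of just one hydrogen for one fluorine atom, and the change from phenyl to 2-fluorophenyl moves the number beyond the scatter. No measurement at hand explains the rise.

On these data alone, what stays open is whether the rise belongs to fluoro itself or would appear with other groups in the same place, such as chloro, methoxy or an amine. The compounds shown also leave open whether fluoro on another carbon of that ring would move the number in the same direction, or at all.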